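The compounds below may be only part of what the source reports. "The series", "measured", "known", "first", "only" and "open" are said of these compounds alone.

Values in a functional assay on U-251 cells (Homo sapiens) for cytotoxicity; on this read-out lower numbers stand for stronger inhibition of growth and higher numbers for weaker inhibition of growth
compound 1 `COc1ccc(C2=C(c3ccc(SC)cc3)CC3CCCN3C2=O)cc1O` gives 5000 nM
compound 2 `COc1ccc(C2=C(c3ccc(SC)cc3)CC3CCCN3C2=O)cc1C` gives 90 nM
compound 3 `CSc1ccc(C2=C(c3ccc(F)c(C)c3)C(=O)N3CCCC3C2)cc1` gives 200 nM

Compound 2 has the lowest number of the three. Next is compound 4 `COc1ccc(C2=C(c3ccc(SC)cc3)CC3CCCN3C2=O)cc1`, which differs from compound 2 thus: hydrogen in place of methyl on an aromatic carbon, ortho to a methoxy group. The closest evidence is a 56-fold lower number from compound 1 to compound 2 (1.74 log units; beyond the scatter), a large step at this same place. Hydrogen there is untested. The step of a 2.2-fold higher number from compound 2 to compound 3 (0.35 log units; beyond the scatter) is modest and concerns the methoxy group and not this place, while a 25-fold lower number from compound 1 to compound 3 (1.40 log units; beyond the scatter) changes both. A modest move to a higher number is expected in this assay, with the direction uncertain. The expected step is a 2.2-fold higher number from compound 2 to compound 4 (0.35 log units; beyond the scatter) in this estimate. For compound 4 the estimated value is 200 nM, with an expected range of 60 nM to 800 nM.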

Compound 4, concentration for 50% growth inhibition: 2000 nM
Estimate against measurement, compound 4: 10-fold (1.00 log units) below; the measured number lies above the stated range.
By their numbers in this assay, from the lowest: compound 2; then compound 3; then compound 4; then compound 1.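

In this assay the methyl group on the 4-methoxy-3-methylphenyl ring carries most of the result, with a 22-fold higher number from compound 2 to compound 4 (1.35 log units; beyond the scatter) when hydrogen replaces it, whereas a 2.5-fold lower number from compound 1 to compound 4 (0.40 log units; beyond the scatter) shows that hydrogen gains only modestly over hydroxy at this place. The order here is therefore methyl, then hydrogen, then hydroxy, and a 10-fold higher number from compound 3 to compound 4 (1.00 log units; beyond the scatter) fits this, since the 4-fluoro-3-methylphenyl ring of compound 3 also keeps the methyl. No measurement bears on why methyl matters at this place.

On these data alone, whether ethyl, chloro or trifluoromethyl at this place would match methyl remains open. Also open, as far as these compounds go, is whether any other group can stand in for the methoxy group without the neighbouring methyl.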